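Swapping a hydrazide tail for a dimethylpyrrole on an amide

The source may report more compounds than this note shows. Statements on the series, on what has been measured and on what is new or still open speak of the compounds shown alone.

The measurements come from an ADME assay on Vero cells (Chlorocebus sabaeus) for cytotoxicity, read by MTT assay, with a stated time of 72 h; a lower number here means a stronger inhibitor, a higher number a weaker inhibitor. Compound 2 `CC(=O)NNC(=O)c1ccc(-n2c(C)ccc2C)cc1` gives 173000 nM there, the lower of the two numbers in hand. Compound 3 `O=C(NNC(=O)c1ccc([N+](=O)[O-])cc1)c1ccc(-n2cccc2)cc1` gives 190000 nM, and the gap between the two lies within the scatter of this assay, so neither can be called the more toxic. In this assay compound 1 `Cc1ccc(C)n1-c1ccc(C(=O)N/N=C/c2ccc(Br)cc2)cc1` gives "not determined" (no result reported), so no number is in hand for it. The next compound, compound 4 `Cc1ccc(C)n1NC(=O)c1ccc(-n2c(C)ccc2C)cc1`, differs from compound 2 in one place: 2,5-dimethyl-1H-pyrrol-1-yl in place of acetamido on an amide-type nitrogen. Among the compounds with values here, no measured pair shows what such a change does here, and both numbers in hand sit close together, so the step from compound 2 to compound 4 is expected to stay within the scatter, with no clear direction. Compound 4 is therefore estimated at 160000 nM, within a range of 60000 nM to 400000 nM, which corresponds to an expected step of a 1.1-fold lower number from compound 2 to compound 4 (0.03 log units; within the scatter).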

Compound 4, half-maximal inhibitory concentration: 230000 nM
Estimate against measurement, compound 4: 1.4-fold (0.16 log units) below; low and high end bracket the measured number.
By their numbers in this assay, from the lowest: compounds 2, 3 and 4 (each within the scatter of the next).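

In this assay, the first single change measured at this position gives a 1.3-fold higher number from compound 2 to compound 4 (0.12 log units; within the scatter), so this amide-type nitrogen accepts a ring without a hydrogen-bond donor in place of acetamido, which carries one, with no shift that stands clear of the scatter. Nothing in hand explains why the two numbers stay so close. Still open, as far as these compounds go, is whether an amine or a longer acyl chain on this same nitrogen would move the number beyond the scatter, in either direction.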